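A few compounds are considered here, and "the series" means these few. Any claim that something is new, unique, unknown or untested is made for them only; others in the source may bear on it.

Measured so far:
compound 1 `CCCCc1cnc(C(CCCC)Cc2ccc(-c3ccccc3C(=O)O)cc2)[nH]1` gives 2660 nM
compound 2 `O=C(O)c1ccccc1-c1ccc(CCc2ncc(Cc3ccccc3F)[nH]2)cc1` gives 177 nM

Both were tested in an in vitro functional assay on cells for agonist activity at Bombesin receptor subtype-3 (Homo sapiens), read by luminescence and calcium flux; a higher number here means that more compound is needed for the effect, a lower number that less compound is needed. Among the compounds with values here, compound 2 stands at the lowest of the two numbers; its only neighbour, compound 1, needs far more compound, and the gap between them lies well beyond the usual scatter of this assay.

Compound 3 `O=C(O)c1ccccc1-c1ccc(CCc2ncc(CCC3CCCCC3)[nH]2)cc1` has not yet been measured. It differs from compound 2 in a single place: cyclohexylmethyl in place of 2-fluorophenyl on a saturated chain carbon bound to an aromatic carbon. The group that leaves and the group that enters are of the same size, but an aromatic ring carrying a fluorine gives way to a saturated ring.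

Within the data shown here, no measured pair isolates this kind of change. Among the measured compounds shown here, the only hint comes from compound 1, which carries saturated chains rather than a fluorinated ring and gives the higher number, though it differs from compound 2 in more than one place, so it cannot settle the question. A moderate rise is expected for the step of a 2.5-fold higher number from compound 2 to compound 3 (0.41 log units; beyond the scatter), probably just beyond the scatter. Compound 3 is therefore expected to give about 450 nM in this assay, within a range from 130 nM to 1600 nM.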

Compound 3, half-maximal effective concentration: 642 nM
Compound 3: middle estimate off by 1.4-fold (0.15 log units), on the low side; the range from low to high includes it.
By their numbers in this assay, from the lowest: compound 2; then compound 3; then compound 1.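

In this assay, replacing 2-fluorobenzyl with 2-cyclohexylethyl on the shared core gives a 3.6-fold higher number from compound 2 to compound 3 (0.56 log units; beyond the scatter), the first sign that this position responds to the kind of group it carries. The step is modest, and compound 3 still gives a measurable value of 642 nM, so among these compounds an aromatic ring carrying a fluorine is not needed at this place for agonist activity at this receptor. Nothing measured here explains the rise, so the step stands as an observation without a known cause.

This single change alters several things at once: the fluorine goes, the aromatic ring gives way to a saturated ring, and the chain leading to the ring differs, so the compounds shown leave open which of these accounts for the step. A plain benzyl group or a 2-phenylethyl group at this place would help separate these parts, and how a group holding an amine would read here also remains an open question.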